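The source may report more compounds than this note shows. Statements on the series, on what has been measured and on what is new or still open speak of the compounds shown alone.

Compound 2, `CCCc1cnc(C(=O)/C=C/c2ccc(O)cc2)cn1`: 399000 nM
Compound 1, `CC(C)(C)c1cnc(C(=O)Nc2cccc(O)c2)cn1`: 478000 nM

Of the compounds shown here, two have been measured in a functional assay on the whole organism for inhibition, with Spinacia oleracea as the target, read by spectrophotometry, with a stated time of 4 h; a higher number here means a weaker inhibitor, a lower number a stronger inhibitor. Compound 2 gives 399000 nM there. Compound 1 sits close by in this assay with 478000 nM, a gap that lies within the usual scatter, so on these numbers the two compounds cannot be told apart, and neither can be called the stronger inhibitor. Among the measured compounds shown here, no pair of measured compounds differs in only one place, so there is no measured step to lean on.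

Compound 3, `CCCCc1cnc(C(=O)/C=C/c2ccc(O)cc2)cn1`, has not yet been measured. It differs from compound 2 by methyl in place of hydrogen on a saturated chain carbon, three bonds along the chain from an aromatic carbon. For the measured compounds named here, nothing among the measured compounds shows what such a change does in this assay. The expected step of a 1.2-fold lower number from compound 2 to compound 3 (0.10 log units; within the scatter) is small, not beyond the scatter, in either direction. Compound 3 is therefore estimated at 320000 nM in this assay, within a range from 120000 nM to 850000 nM.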

Compound 3, half-maximal inhibitory concentration: 306000 nM
Beside the measured number, compound 3's estimate is 1.0-fold (0.02 log units) above it; the measured number falls inside the stated range.
By their numbers in this assay, from the lowest: compounds 3, 2 and 1 (each within the scatter of the next).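

Among the compounds shown here, this is the first measured step between two compounds that differ in one place: going from propyl to butyl gives a 1.3-fold lower number from compound 2 to compound 3 (0.12 log units; within the scatter) in this assay, so the step can be read but shows no real difference. At this position, on a saturated chain carbon three bonds along the chain from an aromatic carbon, adding one methyl therefore leaves the two compounds indistinguishable in this measurement. No separate measurement bears on this result, so the data offer no explanation for it.

On these data alone, whether this chain position tolerates larger changes remains open, since a single small step says little about the trend along a series. A longer chain such as hexyl or octyl, or a chain ending in an amine or a carboxylic acid, could show whether the number here can move beyond the scatter at all.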